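Replacing methoxymethyl with methylsulfanyl on the shared core

The source may report more compounds than this note shows. Statements on the series, on what has been measured and on what is new or still open speak of the compounds shown alone.

Measured compounds:
compound 1 `COCc1nc2nc(C)cc(Nc3ccc(C(F)(F)F)cc3)n2n1`: 6.7 mL.min-1.g-1
compound 2 `CCc1nc2nc(C)cc(Nc3cccc(Cl)c3)n2n1`: 78.3 mL.min-1.g-1
compound 3 `CCC(F)(F)c1nc2nc(C)cc(Nc3ccc(S(F)(F)(F)(F)F)cc3)n2n1`: a limit, < 5 mL.min-1.g-1

Of the compounds shown here, three sharing one core have been tested in an in vitro ADME assay on microsomes from liver (Homo sapiens) for metabolic stability; a higher number here means faster removal of the compound, a lower number slower removal. Compound 1 gives 6.7 mL.min-1.g-1 in this assay. Compound 2 gives 78.3 mL.min-1.g-1, which leaves compound 1 as the lowest of the two numbers, and the gap between compound 1 and compound 2 lies beyond the usual scatter. For compound 3 the assay reports only a limit, < 5 mL.min-1.g-1, and not a number; the limit of < 5 mL.min-1.g-1 in this assay, at which 1 of the 3 values shown sits, shows that one of the three results sits at this limit.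

Compound 4 `CSc1nc2nc(C)cc(Nc3ccc(C(F)(F)F)cc3)n2n1` has not yet been measured. Its structure departs from compound 1 in one place: methylsulfanyl in place of methoxymethyl on an aromatic carbon. For the measured compounds named here, no pair of measured compounds differs in exactly this way, so there is no measured step to lean on for the size or direction of the change.

Starting from the value of compound 1, 6.7 mL.min-1.g-1, compound 4 is expected to give 14 mL.min-1.g-1 in this assay, within 5 mL.min-1.g-1 to 40 mL.min-1.g-1. The step this estimate means, a 2.1-fold higher number from compound 1 to compound 4 (0.32 log units; beyond the scatter), is expected to be modest and uncertain in direction, since the shown data give no pattern for this replacement.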

Compound 4, intrinsic clearance in microsomes: 18.7 mL.min-1.g-1
Beside the measured number, compound 4's estimate is 1.3-fold (0.13 log units) below it; the measured number falls inside the stated range.
By their numbers in this assay, from the lowest: compound 1; then compound 4; then compound 2. At a limit, below all of these: compound 3.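

Methylsulfanyl in place of methoxymethyl, on an aromatic carbon between two ring nitrogen atoms, gives a 2.8-fold higher number from compound 1 to compound 4 (0.45 log units; beyond the scatter) in this assay, the first step on the shared core that can be read for a change in one place only. The earlier compounds shown here could not show this: compound 1, compound 2 and compound 3 differ from each other in more than one place, so none of their gaps could be assigned to this position alone. This step shows that the group at this position can, on its own, shift the number beyond the usual scatter, although nothing shown here accounts for the direction of the shift.

On these data alone, it remains open whether the same replacement would give a similar step on a compound that carries a different group on its other aromatic ring, since one pair cannot establish a trend. Also unresolved is how other groups at this position would compare with methoxymethyl and methylsulfanyl, such as a simple amine, a methoxy group or the longer ethylsulfanyl chain.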